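The source may report more compounds than this note shows. Statements on the series, on what has been measured and on what is new or still open speak of the compounds shown alone.

Measured so far:
compound 1 `O=C(NCCCCn1cccn1)c1cccc(C2SCC(=O)N2c2cccnc2)c1`: > 1000 nM
compound 2 `COc1ccccc1N1C(=O)CSC1c1cccc(C(=O)NCCCCc2ccc(Cl)cc2)c1`: 78.6 nM

In a functional assay on HOS-TE85 cells (Homo sapiens) for inhibition, read by CCK-8 assay, with a stated time of 72 h (a lower number here means a stronger inhibitor, a higher number a weaker inhibitor), compound 1 gives > 1000 nM, which is a limit of the assay and not a number (the limit of > 1000 nM in this assay, at which 1 of the 2 values shown sits). Going by the values given here, compound 2 gives 78.6 nM in this assay, but it differs from compound 1 in more than one place, so no single step is known. Compound 3 `CCOC(=O)c1sc(N2C(=O)CSC2c2cccc(C(=O)NCCCCn3cccn3)c2)nc1C` differs from compound 1 in one place: 5-(ethoxycarbonyl)-4-methyl-1,3-thiazol-2-yl in place of pyridin-3-yl on an amide-type nitrogen in a ring. Among the compounds with values here, no measured step shows what this change does, so the expected step that the limit leaves unreadable from compound 1 to compound 3 is small and uncertain. Compound 3 is estimated at 1500 nM, with a range from 300 nM to 8000 nM.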

Compound 3, half-maximal inhibitory concentration: 430 nM
For compound 3 the middle estimate is 3.5-fold (0.54 log units) above the measured one; the range from low to high includes it.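

Putting 5-(ethoxycarbonyl)-4-methyl-1,3-thiazol-2-yl in place of pyridin-3-yl on the amide-type nitrogen in the ring brings in this assay an at least 2.3-fold lower number from compound 1 to compound 3 (0.36 log units; beyond the scatter) on an otherwise unchanged molecule. Going by these compounds alone, this is the first sign that the group at this position alone can shift the read-out. Compound 1 gives > 1000 nM as a limit of the assay and not a number, so the full size of the step stays unknown: the limit of > 1000 nM in this assay, at which 1 of the 3 values shown sits.

Which part of the new group matters remains open. A plain 1,3-thiazol-2-yl, or a carboxylic acid in place of the ethoxycarbonyl, could separate the ring from its ester.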